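The compounds below may be only part of what the source reports. "The series", "measured", "known", "first", "only" and "open" are said of these compounds alone.

Among the measured compounds shown here, compound 1 `CC(C)Oc1cncc(C2=CC3CNCC(C2)C3)c1` holds the lower of the two numbers measured so far: in an in vitro functional assay on SH-EP1 cells for agonist activity at Neuronal acetylcholine receptor; alpha4/beta2 (Homo sapiens), read by FLIPR and calcium flux (a higher number here means a larger maximal response, a lower number a smaller maximal response), compound 1 gives 75%, while compound 2 `C1=C(c2cccnc2)C[C@H]2CNC[C@@H]1C2` gives 114%, a gap beyond the usual scatter. Compound 3 `COc1cncc(C2=CC3CNCC(C2)C3)c1` is not yet measured. It differs from compound 1 in one place: methyl in place of isopropyl on an oxygen on an aromatic ring. For the measured compounds named here, no measured pair shows this exact change, so the step size is uncertain; a modest rise is expected since compound 2 without any such group reaches 114%. The expected step is a number 15 percentage points higher from compound 1 to compound 3 (beyond the scatter). For compound 3 the estimated maximal response is 90%, likely between 65% and 115%.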

Compound 3, largest response reached (reported as percent of maximum), in percent of the reference or control that the assay uses: 72%
Compound 3: the middle estimate sits 18 percentage points above what was measured; low and high end bracket the measured number.
By their numbers in this assay, from the lowest: compounds 3 and 1 (each within the scatter of the next); then compound 2.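

Swapping isopropoxy for methoxy on the aromatic ring gives a number 3 percentage points lower from compound 1 to compound 3 (within the scatter) in this assay. Among the compounds shown here, at this position, then, the two groups cannot be told apart by maximal response, something no earlier pair could show. Nothing available explains this result. Still open, on these data alone, is whether a larger change on this oxygen, such as a longer chain or a cyclopropylmethyl group, would separate from compound 1. An amine in place of the alkoxy group is equally unresolved.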